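The compounds below may be only part of what the source reports. "The series", "measured", "known", "first", "only" and "open" are said of these compounds alone.

Compound 1, `CS(=O)(=O)Nc1c(O)ccc2c1CCCC2c1c[nH]cn1`, gives 1260 nM in an assay on isolated protein for binding affinity to Alpha-1D adrenergic receptor (Rattus norvegicus), read by radioligand binding; a lower number here means a stronger inhibitor, a higher number a weaker inhibitor.
Compound 2, `CCS(=O)(=O)Nc1cc(C2CCCCC2)cc2c1CCCC2c1c[nH]cn1`, gives 447 nM in this assay.
Compound 3, `CS(=O)(=O)Nc1ccc(O)c2c1CCCC2c1c[nH]cn1`, gives < 10000 nM in this assay, which is a limit of the assay and not a number.

Of the three measured compounds, compound 1 and compound 2 have numbers, while compound 3 stands only at the limit of < 10000 nM in this assay, at which 1 of the 3 values shown sits. Within the data shown here, its true value is therefore not known beyond that mark, and no step to another measured compound can be read from it.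

Compound 4, `COc1ccc(NS(C)(=O)=O)c2c1C(c1c[nH]cn1)CCC2`, differs from compound 3 in one place: methyl in place of hydrogen on an oxygen on an aromatic ring. Among the measured compounds shown here, the single change is a methyl in place of hydrogen on an oxygen on an aromatic ring, so that a hydroxy becomes a methoxy. For the measured compounds named here, since compound 3 has only a limit, no measured step of this kind is available to set the size or direction of the change in this assay; the expectation rests on the range in which compound 1 and compound 2 sit.

Compound 4 is therefore expected to give about 2500 nM in this assay, within 400 nM to 15000 nM. The expected step from compound 3 is a step that the limit leaves unreadable from compound 3 to compound 4, an estimate rather than a measurement.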

Compound 4, inhibition constant: < 10000 nM
Compound 4 ended at the assay's limit; the forecaster's own chance of this, stated with the estimate: 35%; the middle value lies beyond the limit too.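

Compound 3 and compound 4 each stand only at a limit of the assay and not at a number, so no step between them can be read: the limit of < 10000 nM in this assay, at which 2 of the 4 values shown sit.

The compounds shown leave open the size and direction of any change in this assay when a hydroxy becomes a methoxy.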